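The compounds below may be only part of what the source reports. "The series", "measured", "known", "first", "only" and "open" are said of these compounds alone.

Measured in a toxicity assay on NIH3T3 cells (Mus musculus) for cytotoxicity, read by resazurin assay; a lower number here means that less compound is needed, a higher number that more compound is needed for the effect:
Compound 1, `Clc1ccc(Cn2cncc2CNc2cccc(-c3ccccc3)c2)cc1`, gives 10000 nM.
Compound 2, `COC(=O)c1ccc(NCc2cncn2Cc2ccc(Cl)cc2)cc1-c1ccccc1`, gives 25000 nM.
Compound 3, `CCc1ccc(Cn2cncc2CNc2ccc(-c3nc4ccccc4s3)c(-c3ccccc3)c2)cc1`, gives only a limit of the assay, > 1000 nM.

Compound 2 stands highest of the two numbers in this assay; its nearest neighbour is compound 1, and the step of a 2.5-fold higher number from compound 1 to compound 2 (0.40 log units; beyond the scatter), methoxycarbonyl in place of hydrogen on an aromatic carbon, is modest but beyond the scatter. Compound 3 reaches only the limit of > 1000 nM in this assay, at which 1 of the 3 values shown sits, and supplies no number for ranking.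

Compound 4, `COC(=O)c1ccc(NCc2cncn2Cc2ccccc2C)cc1-c1ccccc1`, is not yet measured. It differs from compound 2 by 2-methylphenyl in place of 4-chlorophenyl on a saturated chain carbon bound to an aromatic nitrogen. Among the compounds with values here, no measured step touches the group on the saturated chain carbon bound to an aromatic nitrogen: the one step known, from compound 1 to compound 2, changes another part of the molecule. With nothing bearing on the exchange of the 4-chlorobenzyl for the 2-methylbenzyl, no step beyond the scatter is expected in this assay in either direction. Compound 4 is therefore expected to give 20000 nM, with a range from 8000 nM to 50000 nM. The expected step of a 1.3-fold lower number from compound 2 to compound 4 (0.10 log units; within the scatter) is estimated to sit within the scatter.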

Compound 4, half-maximal effective concentration: 10000 nM
Beside the measured number, compound 4's estimate is 2.0-fold (0.30 log units) above it, within the range that was stated.
By their numbers in this assay, from the lowest: compounds 1 and 4 (each within the scatter of the next); then compound 2.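

In this assay, the group on the saturated chain carbon bound to an aromatic nitrogen now proves able to move the number: a 2.5-fold lower number from compound 2 to compound 4 (0.40 log units; beyond the scatter) is a modest step, with 2-methylphenyl in place of 4-chlorophenyl. Within the data shown here, until now the only step on record was a 2.5-fold higher number from compound 1 to compound 2 (0.40 log units; beyond the scatter), at another part of the molecule, so the series now has one modest step at each of two places, running in opposite directions. Nothing at hand gives a reason for the new step.

The exchange alters both the substituent, chlorine to methyl, and its place on the ring, and the compounds shown do not separate the two. Still open, from the compounds shown here alone, is how 4-methylphenyl, unsubstituted phenyl or a longer chain such as 2-phenylethyl would read at this position.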